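Working notes: from compound 3 to compound 4

The source may hold more compounds than are shown below. What is called first, only, known or untested is meant among the compounds shown, and "the series" means these compounds.

- compound 1 `C=C(Br)C(=O)Nc1ccc(/C=C/C(=O)c2ccccc2)cc1`: 3900 nM
- compound 2 `C=C(Br)C(=O)Nc1ccc(/C=C/C(=O)c2ccc(F)cc2)cc1`: 1400 nM
- compound 3 `C=C(Br)C(=O)Nc1ccc(/C=C/C(=O)c2cccc(OC)c2)cc1`: 700 nM

All three values come from a functional assay on HeLa cells (Homo sapiens) for antiproliferative activity, with a stated time of 48 h; a higher number here means a weaker inhibitor, a lower number a stronger inhibitor. Compound 3 shares the low end of this small set with one neighbour and stands clear of the other. The measured gaps are a 2.0-fold lower number from compound 2 to compound 3 (0.30 log units; within the scatter) and a 5.6-fold lower number from compound 1 to compound 3 (0.75 log units; beyond the scatter).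

Compound 4 `C=C(Br)C(=O)Nc1ccc(/C=C/C(=O)c2cccs2)cc1` brings one change: thiophen-2-yl in place of 3-methoxyphenyl on a carbonyl carbon. Among the compounds with values here, no measured step covers this swap. Both measured gains came from a group added to compound 1, and each was modest: a 2.8-fold lower number from compound 1 to compound 2 (0.44 log units; beyond the scatter) and a 5.6-fold lower number from compound 1 to compound 3 (0.75 log units; beyond the scatter). Compound 4 carries neither fluoro nor methoxy, so part of that gain may not carry over. The expected move in this assay is a modest rise: a 2.6-fold higher number from compound 3 to compound 4 (0.41 log units; beyond the scatter). Compound 4 is estimated at 1800 nM, with an expected range of 600 nM to 5000 nM.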

Compound 4, half-maximal inhibitory concentration: 340 nM
For compound 4 the middle estimate is 5.3-fold (0.72 log units) above the measured one; measured number below the stated range.
By their numbers in this assay, from the lowest: compound 4; then compounds 3 and 2 (each within the scatter of the next); then compound 1.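

In this assay, the group on the carbonyl carbon can gain through a change of ring, not only through an added group: thiophen-2-yl, with neither fluoro nor methoxy, gives a 2.1-fold lower number from compound 3 to compound 4 (0.31 log units; beyond the scatter), a 4.1-fold lower number from compound 2 to compound 4 (0.61 log units; beyond the scatter) and an 11-fold lower number from compound 1 to compound 4 (1.06 log units; beyond the scatter). Compound 4 thus stands beyond the scatter of all three earlier compounds. Nothing at hand accounts for this gain.

Open, from the compounds shown here alone, is whether furan-2-yl in the same place matches thiophen-2-yl. Also open, going by these compounds, is whether a methoxy group or an amine on the thiophen-2-yl ring would add to the gain.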